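A nitrophenyl triazole and a dioxolane-for-phenyl swap

The compounds below may be only part of what the source reports. "The series", "measured", "known", "first", "only" and "open" are said of these compounds alone.

Within the data shown here, compound 1 `O=[N+]([O-])c1ccc(-c2cn(Cc3ccccc3)nn2)cc1` is the only one of three measured compounds to give a number in a functional assay on B16 cells (Mus musculus) for cytotoxicity, read by MTT assay, with a stated time of 48 h; a higher number here means a weaker inhibitor, a lower number a stronger inhibitor: compound 1 gives 5120 nM. Compound 3 `Cc1ccc(C(O)c2cn(Cc3ccccc3)nn2)cc1` gives only a limit of the assay in this assay, > 100000 nM. Compound 2 `Cc1ccc(C(O)c2cn(CC3COC(C)(C)O3)nn2)cc1` likewise gives only a limit in this assay, > 100000 nM. The change 2,2-dimethyl-1,3-dioxolan-4-yl in place of phenyl on a saturated chain carbon bound to an aromatic nitrogen makes a step that the two limits leave unreadable from compound 3 to compound 2; both ends sit at the limit of > 100000 nM in this assay, at which 2 of the 3 values shown sit. How the core of compound 1 differs from the core of compound 3 is not broken down here. Compound 4 `CC1(C)OCC(Cn2cc(-c3ccc([N+](=O)[O-])cc3)nn2)O1` arises from compound 1 by the same change, (2,2-dimethyl-1,3-dioxolan-4-yl in place of phenyl on a saturated chain carbon bound to an aromatic nitrogen). Because compound 1 gives 5120 nM while the earlier step cannot be read, the expected step is estimated at a 2.9-fold higher number from compound 1 to compound 4 (0.47 log units; beyond the scatter). Compound 4 is expected to give 15000 nM in this assay, between 4000 nM and 100000 nM.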

Compound 4, half-maximal inhibitory concentration: > 100000 nM
Compound 4 gave a limit, no number; the forecaster's own chance of this, stated with the estimate: 35%; middle value at least 6.6-fold (0.82 log units) away from the limit.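

In this assay, putting 2,2-dimethyl-1,3-dioxolan-4-yl in place of phenyl on the core of compound 1 gives an at least 19-fold higher number from compound 1 to compound 4 (1.29 log units; beyond the scatter), so on this core the change costs a great deal of cytotoxic strength. As far as these compounds go, compound 4 gives only a limit of the assay, > 100000 nM, so the step is a minimum and its true size stays unknown. The same change on the core of compound 3 cannot be read, so there is only one readable case, and it does not show whether the size of the step carries from one core to another: the limit of > 100000 nM in this assay, at which 3 of the 4 values shown sit.

Still open, from the compounds shown here alone, is how an amine or a carboxylic acid in place of phenyl, on a saturated chain carbon bound to an aromatic nitrogen, would read on the core of compound 1.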